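Swapping the aminocyclobutyl ether for a piperidinyl ether

The source may hold more compounds than are shown below. What is called first, only, known or untested is meant among the compounds shown, and "the series" means these compounds.

Three compounds have been examined in an assay on isolated protein for inhibition of ubiquitin carboxyl-terminal hydrolase 7 (Homo sapiens), read by fluorescence, with stated times of 30 min and 1 h; on this read-out lower numbers stand for stronger inhibition and higher numbers for weaker inhibition. Compound 1 `Cc1cc(Cl)cc(-c2ccnc3cc(CN4C(=O)CCC4=O)sc23)c1O[C@H]1C[C@H](N)C1` gives 3.4 nM in this assay. Compound 2 `Cc1cc(Cl)cc(-c2ccnc3cc(CN4C(=O)C5C(C4=O)C5(C)C)sc23)c1CC1CCCNC1`, which carries a different ring system on the shared core, gives 1.3 nM in this assay, and compound 3 `O=C([C@H]1Cc2cc(Cl)cc(-c3ccnc4cc(C(O)(CO)CCl)sc34)c2O1)N1CCNCC1`, built on another scaffold, gives 9 nM in this assay. Among these three numbers compound 1 stands second highest: its nearest neighbour is compound 2, whose number lies below it by a margin that is beyond the scatter, and its furthest neighbour is compound 3, whose number lies above it by a margin that is also beyond the scatter.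

The next compound, compound 4 `Cc1cc(Cl)cc(-c2ccnc3cc(CN4C(=O)CCC4=O)sc23)c1OC1CCNCC1`, differs from compound 1 in one place: piperidin-4-yl in place of 3-aminocyclobutyl on an oxygen on an aromatic ring. Both the leaving group and the entering group carry one hydrogen-bond donor and one hydrogen-bond acceptor and have no net charge; the ring grows from four members of carbon only to six members with one hetero atom, and the two defined stereocentres are lost. Going by the values given here, no measured pair shows this exact change, so the comparison rests on compound 1 alone.

Compound 4 is expected to remain close to compound 1, with a step from a 1.2-fold higher number from compound 1 to compound 4 (0.07 log units; within the scatter) that stays within the scatter. The estimate for compound 4 in this assay is 4 nM, with a range from 1.5 nM to 12 nM.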

Compound 4, half-maximal inhibitory concentration: 8 nM
Estimate against measurement, compound 4: 2.0-fold (0.30 log units) below; low and high end bracket the measured number.
By their numbers in this assay, from the lowest: compound 2; then compound 1; then compounds 4 and 3 (each within the scatter of the next).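

In this assay, moving to piperidin-4-yl on an oxygen on an aromatic ring gives a 2.4-fold higher number from compound 1 to compound 4 (0.37 log units; beyond the scatter), a modest step but one beyond the scatter, which shows that this position responds to the ring it carries. The leaving and entering groups have the same counts of hydrogen-bond donors and acceptors and neither has a net charge, so matching those counts did not keep the number in place; ring size, the ring nitrogen and the two defined stereocentres all change together, and this single step cannot separate them. No supporting evidence accompanies the step, and the source of the difference remains unexplained.

The compounds shown leave open which of those changes matters, a question that a 4-aminocyclohexyl group, which keeps a primary amine outside the ring, or a pyrrolidin-3-yl group, which has a smaller ring with the nitrogen inside it, could help to address on the same oxygen. They also leave open whether the step would carry over to a core bearing a different group in place of the succinimide-derived ring of compound 1.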